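Swapping (dimethylamino)methyl for carboxy on an amide chain

The source may hold more compounds than are shown below. What is called first, only, known or untested is meant among the compounds shown, and "the series" means these compounds.

Two related compounds have been measured so far in a functional assay on PC-3 cells (Homo sapiens) for antiproliferative activity, read by MTT assay, with a stated time of 72 h (on this read-out lower numbers stand for stronger inhibition and higher numbers for weaker inhibition), and both sit at weak inhibition on its scale. Compound 1 (`CCn1c(C(=O)NCCC(=O)OC)ccc1C(CC)(CC)c1ccc(C#CC(O)(CC)CC)c(C)c1`) reads 36300 nM there, while compound 2 (`CCn1cc(C(CC)(CC)c2ccc(C#CC(O)(CC)CC)c(C)c2)cc1C(=O)NCCN(C)C`) reads 10100 nM on the same scale. Compound 2 therefore holds the lower of the two numbers, and the gap between them lies beyond the usual scatter. These two compounds differ in more than one place, so their gap cannot be tied to any single change.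

Compound 3 (`CCn1cc(C(CC)(CC)c2ccc(C#CC(O)(CC)CC)c(C)c2)cc1C(=O)NCC(=O)O`) keeps the rest of compound 2 and carries carboxy in place of (dimethylamino)methyl on a saturated chain carbon bound to an amide-type nitrogen. Going by the values given here, no measured pair isolates this change, so the data offer only a thin guide. Compound 1, which also lacks (dimethylamino)methyl, reads 36300 nM and hints at weaker inhibition. A moderate change towards weaker inhibition is therefore expected, estimated as a 2.0-fold higher number from compound 2 to compound 3 (0.30 log units; within the scatter) in this assay with no great confidence. Compound 3 is expected at 20000 nM with an estimated range of 8000 nM to 50000 nM as the likely span.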

Compound 3, half-maximal inhibitory concentration: 6300 nM
For compound 3 the middle estimate is 3.2-fold (0.50 log units) above the measured one; the whole stated range lies above it.
By their numbers in this assay, from the lowest: compounds 3 and 2 (each within the scatter of the next); then compound 1.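

Going by these compounds alone, this step is the first read on a single change at this position: in this assay, carboxy in place of (dimethylamino)methyl on a saturated chain carbon bound to an amide-type nitrogen gives a 1.6-fold lower number from compound 2 to compound 3 (0.20 log units; within the scatter) and so leaves the read-out inside the usual scatter. The group that enters has one hydrogen-bond donor and the group that leaves has none, and the two also differ in heavy atoms, yet compound 2 and compound 3 cannot be told apart on this scale. At this place, then, the two chain ends read alike in this one pair, and no measurement at hand offers an explanation for that.

The compounds shown leave open whether a primary amine or a hydroxyl at this chain end, or a free carboxylic acid on a longer chain, would also read alike or would move the number beyond the scatter. They also leave open whether the same swap would read alike on a core with a different substitution pattern, or in a different assay.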